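Benzyl on the Pyrimidinedione Nitrogen of Two Conjugates

A few compounds are considered here, and "the series" means these few. Any claim that something is new, unique, unknown or untested is made for them only; others in the source may bear on it.

The set comprises four compounds that share a lactone-bearing core joined through an ester to a fluorinated pyrimidinedione. Compound 1 `C=C1C(=O)O[C@H]2[C@H]1CC/C(COC(=O)Cn1cc(F)c(=O)[nH]c1=O)=C\CC[C@@]1(C)O[C@@H]21` carries the pyrimidinedione on a short linker, and compound 2 `C=C1C(=O)O[C@H]2[C@H]1CC/C(COC(=O)CCC(=O)N1CCN(C(=O)Cn3cc(F)c(=O)[nH]c3=O)CC1)=C\CC[C@@]1(C)O[C@@H]21` carries it on a longer linker; the difference between the two cores is not broken down here. Compound 3 `C=C1C(=O)O[C@H]2[C@H]1CC/C(COC(=O)Cn1cc(F)c(=O)n(Cc3ccccc3)c1=O)=C\CC[C@@]1(C)O[C@@H]21` and compound 4 `C=C1C(=O)O[C@H]2[C@H]1CC/C(COC(=O)CCC(=O)N1CCN(C(=O)Cn3cc(F)c(=O)n(Cc4ccccc4)c3=O)CC1)=C\CC[C@@]1(C)O[C@@H]21` are the benzylated counterparts of compound 1 and compound 2.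

In a functional assay on Bel-7402 cells (Homo sapiens) for antiproliferative activity, read by MTT assay, with a stated time of 72 h (a lower number here means a stronger inhibitor, a higher number a weaker inhibitor), compound 1 gives > 20000 nM, which is a limit of the assay rather than a number. Compound 2 likewise gives > 20000 nM in this assay, again only a limit. Compound 3 gives 3980 nM in this assay. The change from compound 1 to compound 3 is benzyl in place of hydrogen on an aromatic nitrogen and produces an at least 5.0-fold lower number from compound 1 to compound 3 (0.70 log units; beyond the scatter); the step is stated as a minimum because of the limit of > 20000 nM in this assay, at which 2 of the 3 values shown sit.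

The change from compound 2 to compound 4 is benzyl in place of hydrogen on an aromatic nitrogen, the same change, at the same place around the ring. Among the measured compounds shown here, it is expected to produce a step of about an at least 2.5-fold lower number from compound 2 to compound 4 (0.39 log units; beyond the scatter), resting on the only measured example, the step from compound 1 to compound 3 of an at least 5.0-fold lower number from compound 1 to compound 3 (0.70 log units; beyond the scatter). Compound 4 is therefore estimated at 8000 nM in this assay, with a plausible range from 2500 nM to 30000 nM, and the chance remains that only a limit is reported.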

Compound 4, half-maximal inhibitory concentration: > 20000 nM
Compound 4 was reported as a limit (the forecaster's own chance of this, stated with the estimate: 35%); middle value at least 2.5-fold (0.39 log units) from the limit.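

In this assay compound 4 gives > 20000 nM, which is a limit of the assay and not a number. Among the compounds shown here, compound 2 also stands at a limit, so no step from compound 2 to compound 4 can be read: the limit of > 20000 nM in this assay, at which 3 of the 4 values shown sit. The compounds shown leave open whether benzyl on the aromatic nitrogen lowers the number on the longer linker, as it does on the short linker of compound 1 and compound 3.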